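Demethylation of the aryl methoxy group in a diaryl urea pyrazole

The source may hold more compounds than are shown below. What is called first, only, known or untested is meant among the compounds shown, and "the series" means these compounds.

Compound 1 `O=C(Nc1cccc(-n2cc(-c3ccncc3)c(-c3ccc(Cl)c(O)c3)n2)c1)Nc1ccc(Cl)c(Cl)c1` gives 29600 nM in a functional assay on HCT-15 cells (Homo sapiens) for inhibition, read by sulforhodamine B assay, with a stated time of 48 h; on this read-out higher numbers stand for weaker inhibition of growth and lower numbers for stronger inhibition of growth.
Compound 2 `COc1cc(-c2nn(-c3cccc(NC(=O)Nc4ccc(Cl)c(C(F)(F)F)c4)c3)cc2-c2ccncc2)ccc1Cl` gives 7050 nM in this assay.

Of these two numbers compound 2 has the lower one, and compound 1 stands beyond the scatter above it. Compound 3 `O=C(Nc1cccc(-n2cc(-c3ccncc3)c(-c3ccc(Cl)c(O)c3)n2)c1)Nc1ccc(Cl)c(C(F)(F)F)c1` differs from compound 2 in one place: hydrogen in place of methyl on an oxygen on an aromatic ring. Going by the values given here, compound 1 already carries the hydroxy group and shows the higher number, but it also differs from compound 2 elsewhere, so no single step is known. Compound 3 is therefore expected to move toward weaker inhibition, by a 2.1-fold higher number from compound 2 to compound 3 (0.33 log units; beyond the scatter), but not with confidence. The estimate for compound 3 is 15000 nM, within 5000 nM to 45000 nM.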

Compound 3, concentration for total growth inhibition: 13800 nM
Compound 3: middle estimate off by 1.1-fold (0.04 log units), on the high side, within the range that was stated.
By their numbers in this assay, from the lowest: compounds 2 and 3 (each within the scatter of the next); then compound 1.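

In this assay, going by these compounds alone, the change from methoxy to hydroxy on the aromatic ring, read alone for the first time, is a 2.0-fold higher number from compound 2 to compound 3 (0.29 log units; within the scatter) and so cannot be told apart from repeat variation. With the hydroxy group held fixed, trifluoromethyl in place of chloro gives a 2.1-fold lower number from compound 1 to compound 3 (0.33 log units; beyond the scatter) and is a modest but readable step. No measured property is available to explain either step. The compounds shown leave open how an amine or an ethoxy group would read at this place on the ring.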